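This account rests on a few compounds, and the source may have more. Where it says the series, first, only, none or still open, it means among the compounds named here.

Values in a functional assay for inhibition; on this read-out higher numbers stand for weaker inhibition and lower numbers for stronger inhibition:
- compound 1 `CC(C)(C)c1cc(-c2cc(=O)c3ccc(OCCO)cc3o2)cc(C(C)(C)C)c1O`: 3000 nM
- compound 2 `CC(C)(C)c1cc(-c2cc(=O)c3ccc(OCCCS(=O)(=O)O)cc3o2)cc(C(C)(C)C)c1O`: 500 nM
- compound 3 `CC(C)(C)c1cc(-c2cc(=O)c3ccc(OCC(=O)N4CCCCC4)cc3o2)cc(C(C)(C)C)c1O`: 3000 nM

Compound 3 stands level with compound 1 at the digits shown, and the gap to the remaining measured compound is a 6.0-fold higher number from compound 2 to compound 3 (0.78 log units; beyond the scatter). The next step leads to compound 4 `CC(C)(C)c1cc(-c2cc(=O)c3ccccc3o2)cc(C(C)(C)C)c1O`, with hydrogen in place of ((piperidin-1-yl)carbonyl)methoxy on an aromatic carbon.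

For the measured compounds named here, no measured pair removes the side chain entirely, so the evidence is indirect. Exchanging the chain end gave no change at the digits printed from compound 1 to compound 3 (within the scatter). Going by the values given here, the only measured change beyond the scatter was a 6.0-fold lower number from compound 1 to compound 2 (0.78 log units; beyond the scatter), with sulfomethyl in place of hydroxy, and compound 4 carries no such group. In this assay, no shift beyond the scatter is therefore expected, though with wide uncertainty. The expected step is no change at the digits printed from compound 3 to compound 4 (within the scatter). For compound 4 the estimated value is 3000 nM, with an expected range of 900 nM to 10000 nM.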

Compound 4, half-maximal inhibitory concentration: 3000 nM
The estimate for compound 4 equals the measured number at the digits printed, and the stated range covers the measured number.
By their numbers in this assay, from the lowest: compound 2; then compounds 1, 3 and 4 (each within the scatter of the next).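

In this assay, hydrogen on this aromatic carbon gives no change at the digits printed from compound 3 to compound 4 (within the scatter) and no change at the digits printed from compound 1 to compound 4 (within the scatter) on the same read-out, so neither ((piperidin-1-yl)carbonyl)methoxy nor 2-hydroxyethoxy separates from the bare position. Against that baseline, the 3-sulfopropoxy chain stands apart, with a 6.0-fold higher number from compound 2 to compound 4 (0.78 log units; beyond the scatter) once it is replaced by hydrogen, so among the compounds shown, the lower number goes with this one substituent and not with the presence of a side chain as such.

As far as these compounds go, whether a carboxylic acid at the chain end would match the 3-sulfopropoxy group remains open, as does the effect of a shorter or longer sulfonated chain. An amine at the chain end is also untested in the compounds shown.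

No measurement shown accounts for the difference between these substituents.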